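The compounds below may be only part of what the source reports. "The series", "measured", "known", "first", "only" and "open" are said of these compounds alone.

Compounds measured so far:
compound 1, `Cc1cc(OCc2nc3ccccc3s2)ccc1NC(=O)Nc1ccc(Cl)cc1`, 570 nM;
compound 2, `O=C(Nc1ccccc1)Nc1ccc(OCc2nc3ccccc3s2)cc1`, 420 nM.

Two ureas carrying the same benzothiazolylmethoxy-substituted aryl urea core have been tested in an assay on isolated protein for inhibition of Polyunsaturated fatty acid 5-lipoxygenase (Homo sapiens), read by HPLC, with a stated time of 10 min; on this read-out higher numbers stand for weaker inhibition and lower numbers for stronger inhibition. Compound 1 gives 570 nM. Compound 2 gives 420 nM and stands with the lowest of the two numbers, but its gap to compound 1 lies within the scatter, so the two cannot be ranked against each other.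

Compound 3, `O=C(Nc1ccc(Cl)cc1)Nc1ccc(OCc2nc3ccccc3s2)cc1`, has not been measured in this assay . It differs from compound 2 in one place: chloro in place of hydrogen on an aromatic carbon. Compound 1 also carries such a chlorine, along with a further methyl group, and its value sits close to that of compound 2, so no step beyond the scatter is expected for this change. Compound 3 is therefore expected to give 450 nM, with a range of 200 nM to 1000 nM, which means an expected step of a 1.1-fold higher number from compound 2 to compound 3 (0.03 log units; within the scatter).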

Compound 3, half-maximal inhibitory concentration: 1010 nM
The estimate for compound 3 lay 2.2-fold (0.35 log units) below the measured number; measured number outside the range, above it.
By their numbers in this assay, from the lowest: compounds 2, 1 and 3 (each within the scatter of the next, the first and the last beyond it).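

In this assay, among these compounds, the change from phenyl to 4-chlorophenyl gives the first step beyond the scatter: a 2.4-fold higher number from compound 2 to compound 3 (0.38 log units; beyond the scatter). So this position, para to a large group, does not take a chloro in place of hydrogen without a readable rise in the number, whereas hydrogen in place of methyl on an aromatic carbon, with the chlorine present, gives a 1.8-fold higher number from compound 1 to compound 3 (0.25 log units; within the scatter). Nothing measured here bears on why the chloro has this effect.

On these data alone, it remains open whether a fluoro, a methoxy or a carboxylic acid at the same position would give a similar step, or whether the step is specific to chloro. Also open, as far as these compounds go, is whether a methyl group alone, without the chlorine, would change the number for compound 2.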